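The compounds below may be only part of what the source reports. "The series", "measured", "known", "first", "only" and "open" are said of these compounds alone.

Measured compounds:
compound 1, `Cn1nnnc1SCC(=O)N/N=C/c1ccccc1`: 9700000 nM
compound 2, `Cc1ccc(/C=N/NC(=O)CSc2nnnn2C)cc1`: 3160000 nM
compound 3, `Cn1nnnc1SCC(=O)N/N=C/c1ccc(Br)cc1`: 10000000 nM

In an ADME assay on NIH3T3 cells (Mus musculus) for cytotoxicity, read by XTT assay, with a stated time of 24 h (a higher number here means a weaker inhibitor, a lower number a stronger inhibitor), compound 1 gives 9700000 nM, the second highest of the three numbers. Compound 3 is the nearest, with 10000000 nM, and the two lie within the scatter of each other; compound 2 is the furthest, with 3160000 nM. The two measured substitutions on the ring of compound 1 point in different directions: a 3.1-fold lower number from compound 1 to compound 2 (0.49 log units; beyond the scatter), whereas a 1.0-fold higher number from compound 1 to compound 3 (0.01 log units; within the scatter). Between the two substituted analogues, a 3.2-fold higher number from compound 2 to compound 3 (0.50 log units; beyond the scatter).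

Compound 4, `Cn1nnnc1SCC(=O)N/N=C/c1ccccc1O`, differs from compound 1 by hydroxy in place of hydrogen on an aromatic carbon, on an aromatic carbon of a six-membered aromatic ring of carbon only, ortho to a large group. Among the measured compounds shown here, no measured step introduces a hydroxy anywhere, so the only guidance is that a substitution on this ring has moved this assay by at most a modest amount, and in one of two cases not at all. A step beyond the scatter in either direction cannot be excluded, but none is expected with confidence.

Compound 4 is therefore estimated at 8000000 nM, in the range 3000000 nM to 15000000 nM, which means an expected step of a 1.2-fold lower number from compound 1 to compound 4 (0.08 log units; within the scatter).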

Compound 4, half-maximal inhibitory concentration: > 10000000 nM
Compound 4 was reported as a limit; the forecaster's own chance of this, stated with the estimate: 20%; middle value at least 1.2-fold (0.09 log units) from the limit.
By their numbers in this assay, from the lowest: compound 2; then compounds 1 and 3 (each within the scatter of the next).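

In this assay compound 4 gives > 10000000 nM, which is a limit of the assay and not a number. The step is read only as a floor, an at least 1.0-fold higher number from compound 1 to compound 4 (0.01 log units; that floor lies within the scatter), so hydroxy in place of hydrogen on an aromatic carbon, ortho to a large group, gives no sign of the lower number seen with methyl in a 3.1-fold lower number from compound 1 to compound 2 (0.49 log units; beyond the scatter), and the floor alone does not separate it from the unsubstituted compound 1. This adds a new group and a new place on the ring to the earlier picture, but only one side of the reading is bounded, and its size stays unknown at the top of the measurable range: the limit of > 10000000 nM in this assay, at which 1 of the 4 values shown sits.

On these data alone, whether the hydroxy itself matters or any group at this place would give the same reading stays open, and an amine or a methoxy at the same place would bear on that. Also open, as far as these compounds go, is whether hydroxy elsewhere on the ring would follow the methyl of compound 2 or the bromo of compound 3, since position and group cannot be told apart from these compounds.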